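This account rests on a few compounds, and the source may have more. Where it says the series, first, only, none or still open, it means among the compounds named here.

Measured compounds:
compound 1 `Cc1cc(N2CC[C@@H](C)[C@@H](N(C)c3ncnc4[nH]ccc34)C2)n2nc(SCC3CC3)nc2n1` with 36500 nM
compound 2 `Cc1cc(N2CC[C@@H](C)[C@@H](N(C)c3ncnc4[nH]ccc34)C2)n2nc(SCc3cc(Cl)ccc3Cl)nc2n1` with 18900 nM
compound 3 `Cc1cc(N2CC[C@@H](C)[C@@H](N(C)c3ncnc4[nH]ccc34)C2)n2nc(SCc3ccc([N+](=O)[O-])cc3)nc2n1` with 59600 nM

All three share one core and differ only in the group on a saturated chain carbon bound to a sulfur. In a functional assay on BGC-823 cells (Homo sapiens) for inhibition, read by MTT assay, with a stated time of 72 h (a higher number here means a weaker inhibitor, a lower number a stronger inhibitor), compound 1 gives 36500 nM, which is the second highest of the three numbers; compound 3 is nearest to it and compound 2 is furthest from it, and both of those gaps stay within the scatter. The change to compound 4 `Cc1cc(N2CC[C@@H](C)[C@@H](N(C)c3ncnc4[nH]ccc34)C2)n2nc(SCc3ccc(F)c(Cl)c3)nc2n1` is 3-chloro-4-fluorophenyl in place of cyclopropyl on a saturated chain carbon bound to a sulfur.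

Going by the values given here, two measured steps bear on this change, both starting from compound 1 and both swapping the cyclopropyl for a substituted phenyl. Going to the 2,5-dichlorophenyl gave a 1.9-fold lower number from compound 1 to compound 2 (0.29 log units; within the scatter), and going to the 4-nitrophenyl gave a 1.6-fold higher number from compound 1 to compound 3 (0.21 log units; within the scatter). Between those two phenyl groups the step was a 3.2-fold higher number from compound 2 to compound 3 (0.50 log units; beyond the scatter). The 3-chloro-4-fluorophenyl of compound 4 carries halogens only, like the group in compound 2, so the step from compound 1 is expected to be small, if anything toward a lower number, and likely within the scatter: a 1.5-fold lower number from compound 1 to compound 4 (0.16 log units; within the scatter). For compound 4 in this assay the estimate is 25000 nM, with a range from 10000 nM to 60000 nM.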

Compound 4, half-maximal inhibitory concentration: 98900 nM
For compound 4 the middle estimate is 4.0-fold (0.60 log units) below the measured one, outside the stated range (above it).
By their numbers in this assay, from the lowest: compounds 2, 1, 3 and 4 (each within the scatter of the next, the first and the last beyond it).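

At this position, carrying only halogens on the phenyl ring does not settle the outcome in this assay: the 3-chloro-4-fluorophenyl and 2,5-dichlorophenyl groups are set apart by a clear gap (a 5.2-fold higher number from compound 2 to compound 4 (0.72 log units; beyond the scatter)). Compound 4 also shows that replacing cyclopropyl with a substituted phenyl can shift the number beyond the scatter (a 2.7-fold higher number from compound 1 to compound 4 (0.43 log units; beyond the scatter)), which neither earlier replacement did, while the 3-chloro-4-fluorophenyl and 4-nitrophenyl groups cannot be told apart (a 1.7-fold higher number from compound 3 to compound 4 (0.22 log units; within the scatter)). Nothing available explains the gap between the two halogen-bearing groups.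

The compounds shown hold only cyclopropyl and substituted phenyl groups on this saturated chain carbon bound to a sulfur, so it remains open how a plain phenyl, a phenyl bearing a single chlorine or a single fluorine, a longer chain, an amine or a carboxylic acid would read here. From the compounds shown here alone, it also remains open whether the gap between compound 2 and compound 4 follows the identity of the halogens, their places on the ring, or both, since these two groups differ in both respects.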